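Bromo added to compound 2: working notes

A few compounds are considered here, and "the series" means these few. Any claim that something is new, unique, unknown or untested is made for them only; others in the source may bear on it.

compound 1 `COc1cc(-c2ocnc2-c2cc(Br)c(OC)c(OC)c2)ccc1SC`: 260 nM
compound 2 `COc1cc(-c2ocnc2-c2cc(OC)c(OC)c(OC)c2)ccc1SC`: 430 nM
compound 3 `COc1ccc(-c2ocnc2-c2cc(OC)c(OC)c(OC)c2)cc1S`: 1280 nM

All three numbers come from an ADME assay on HaCaT cells (Homo sapiens) for cytotoxicity, read by MTT assay, with a stated time of 48 h; a lower number here means a stronger inhibitor, a higher number a weaker inhibitor. In this assay compound 2, at 430 nM, cannot be told apart from compound 1, at 260 nM. Both numbers lie below that of compound 3, at 1280 nM, and the gap from compound 2 to compound 3 is beyond the scatter.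

Compound 4 `COc1cc(-c2ncoc2-c2cc(Br)c(SC)c(OC)c2)cc(OC)c1OC` is not yet measured. Its difference from compound 2 is bromo in place of hydrogen on an aromatic carbon, ortho to a methylsulfanyl group.

Among the compounds with values here, only one measured step involves bromo: a 1.7-fold higher number from compound 1 to compound 2 (0.22 log units; within the scatter), with methoxy in place of bromo on an aromatic carbon. That step lies within the scatter, but it is a swap at another site and only an indirect guide. Within the data shown here, no measured step adds bromo at the site changed here, so the uncertainty stays wide.

No step beyond the scatter is expected in this assay. The expected step is a 1.2-fold lower number from compound 2 to compound 4 (0.09 log units; within the scatter).

For compound 4 the estimate is 350 nM, with an expected range of 130 nM to 950 nM.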

Compound 4, half-maximal inhibitory concentration: 16700 nM
Beside the measured number, compound 4's estimate is 48-fold (1.68 log units) below it; measured number above the stated range.
By their numbers in this assay, from the lowest: compounds 1 and 2 (each within the scatter of the next); then compound 3; then compound 4.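

In this assay bromo in place of hydrogen on an aromatic carbon, ortho to a methylsulfanyl group, gives a 39-fold higher number from compound 2 to compound 4 (1.59 log units; beyond the scatter) and so marks this carbon as a place where a single added atom can cost a great deal of inhibition. Within the data shown here, the only earlier step involving bromo, methoxy in place of bromo at another site, is a 1.7-fold higher number from compound 1 to compound 2 (0.22 log units; within the scatter) and stays within the scatter, so the two sites clearly do not respond alike to this halogen. No measurement at hand accounts for the loss.

Open, as far as these compounds go, is whether the loss belongs to bromo itself or would follow any group on this carbon. Fluoro, chloro, methyl or an amine at the same place would separate those two readings.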